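The compounds below may be only part of what the source reports. "The series", "measured", "known", "first", "only" and "open" are said of these compounds alone.

The compounds measured in a functional assay on A549 cells (Homo sapiens) for antiproliferative activity, read by sulforhodamine B assay, with a stated time of 48 h, tested at 10 uM (a lower number here means less inhibition, a higher number more inhibition at the concentration tested (going by the name of the read-out)), are:

compound 1, `CCCCCCCCCCCCCC[C@H](OCOC)[C@H](CN(CC)CC)NC(=O)OC(C)(C)C`: 27.5%
compound 2, `CCCCCCCCCCCCCC[C@H](OCOC)[C@H](CN(C(C)C)C(C)C)NC(=O)OC(C)(C)C`: 22.6%
compound 3, `CCCCCCCCCCCCCC[C@H](OCOC)[C@H](CN(CCCC)CCCC)NC(=O)OC(C)(C)C`: 42.2%

Compound 3 gives the highest of the three numbers. The steps of a number 14.7 percentage points higher from compound 1 to compound 3 (beyond the scatter) and a number 19.6 percentage points higher from compound 2 to compound 3 (beyond the scatter) both lie beyond the scatter, whereas a number 4.9 percentage points lower from compound 1 to compound 2 (within the scatter) lies within it, so compound 1 and compound 2 cannot be ordered against each other. Compound 4, `CCCCCCCCCCCCCC[C@H](OCOC)[C@H](CN1CCCCC1)NC(=O)OC(C)(C)C`, has not yet been measured. It differs from compound 3 by piperidin-1-yl in place of dibutylamino on a saturated chain carbon, two bonds along the chain from an amide-type nitrogen. Among the compounds with values here, no measured step covers this exact change. Within the data shown here, the steps that bear on it are the two that alter the groups on the amine nitrogen, a number 14.7 percentage points higher from compound 1 to compound 3 (beyond the scatter) and a number 19.6 percentage points higher from compound 2 to compound 3 (beyond the scatter); both show dibutylamino giving a modest gain over diethylamino and diisopropylamino. Since the counted difference shows piperidin-1-yl entering with fewer heavy atoms than dibutylamino leaves, a modest downward step is expected for compound 4, a number 12.2 percentage points lower from compound 3 to compound 4 (beyond the scatter). Compound 4 is therefore estimated to give 30%, within the range 16% to 44%.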

Compound 4, a percentage reported as inhibition, at one concentration (the size of the read-out at that concentration, not a potency): 19%
Compound 4: the middle estimate sits 11 percentage points above what was measured; the range from low to high includes it.
By their numbers in this assay, from the lowest: compounds 4, 2 and 1 (each within the scatter of the next); then compound 3.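

In this assay, piperidin-1-yl in place of dibutylamino on a saturated chain carbon, two bonds along the chain from an amide-type nitrogen, gives a number 23.2 percentage points lower from compound 3 to compound 4 (beyond the scatter), a modest step. Against the other two amines the ring brings no separation: a number 3.6 percentage points lower from compound 2 to compound 4 (within the scatter) and a number 8.5 percentage points lower from compound 1 to compound 4 (within the scatter) both stay within the scatter, so compound 4 cannot be ordered against compound 1 or compound 2. Compound 3 now stands apart from all three other compounds, and the piperidin-1-yl ring does not share its higher number.

No evidence is available that accounts for this separation. The compounds shown leave open whether dihexylamino, with longer chains on the amine nitrogen, or a morpholin-4-yl ring would fall with compound 3 or with compound 4.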